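This account rests on a few compounds, and the source may have more. Where it says the series, first, only, none or still open, it means among the compounds named here.

Measured in an ADME assay (liver) for metabolic stability, with Liver microsome (Rattus norvegicus) as the target, using microsomes and NADPH, with a stated time of 30 min, at 37 degrees C, tested at 1 uM; a higher number here means faster removal of the compound, a lower number slower removal:
- compound 1 `CNc1nc(S(=O)(=O)c2ccc(N)nc2)ccc1-c1ccc(C(C)(O)C(F)(F)F)cn1`: 21 mL.min-1.g-1
- compound 2 `CC(C)Nc1nc(S(=O)(=O)c2ccc(N)nc2)ccc1-c1ccc(C(C)(O)C(F)(F)F)cn1`: 62 mL.min-1.g-1
- compound 3 `CC(O)(c1ccc(-c2ccc(S(=O)(=O)c3ccc(N)nc3)nc2NC2CC2)nc1)C(F)(F)F`: 43 mL.min-1.g-1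

Compound 3, at 43 mL.min-1.g-1, is clearly separated from only one of the other two. The comparison with compound 1 shows a 2.0-fold higher number from compound 1 to compound 3 (0.31 log units; beyond the scatter), whereas the comparison with compound 2 shows a 1.4-fold lower number from compound 2 to compound 3 (0.16 log units; within the scatter), so those two cannot be told apart.

Compound 4 `CC(O)(c1ccc(-c2ccc(S(=O)(=O)c3ccc(N)nc3)nc2NCc2ccccc2)nc1)C(F)(F)F` keeps the shared core and alters one group: benzyl in place of cyclopropyl on a nitrogen on an aromatic ring. This places benzyl in place of cyclopropyl on a nitrogen on an aromatic ring.

Two measured changes at this same nitrogen offer guidance. Replacing methyl gave a 3.0-fold higher number from compound 1 to compound 2 (0.47 log units; beyond the scatter) and a 2.0-fold higher number from compound 1 to compound 3 (0.31 log units; beyond the scatter), both modest and both upward. Neither of these steps brings in an aromatic ring, so the guidance is indirect. A modest upward step is therefore expected, and the estimated step is a 2.1-fold higher number from compound 3 to compound 4 (0.32 log units; beyond the scatter). For compound 4 the estimated value is 90 mL.min-1.g-1, with an expected range of 45 mL.min-1.g-1 to 180 mL.min-1.g-1.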

Compound 4, intrinsic clearance in microsomes: 114 mL.min-1.g-1
Estimate against measurement, compound 4: 1.3-fold (0.10 log units) below, within the range that was stated.
By their numbers in this assay, from the lowest: compound 1; then compounds 3, 2 and 4 (each within the scatter of the next, the first and the last beyond it).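

In this assay, this nitrogen now carries an aromatic ring, and benzyl gives a 2.7-fold higher number from compound 3 to compound 4 (0.42 log units; beyond the scatter) and also a 5.4-fold higher number from compound 1 to compound 4 (0.73 log units; beyond the scatter) in the largest step among these compounds. Against isopropyl the picture differs: the comparison shows a 1.8-fold higher number from compound 2 to compound 4 (0.26 log units; within the scatter) and the two cannot be told apart, so benzyl stands clearly apart only from cyclopropyl and methyl. Nothing measured here explains these differences.

The compounds shown leave open whether the aromatic ring itself matters or whether the count of carbons in the group is enough, and a cyclohexylmethyl group, with the same carbon count as benzyl but no aromatic ring, would separate the two. A longer chain such as phenethyl would show whether moving the ring further from the nitrogen changes the number.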